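A Bromo-to-Chloro Swap on an Aromatic Carbon

The source may hold more compounds than are shown below. What is called first, only, known or untested is meant among the compounds shown, and "the series" means these compounds.

Of the compounds shown here, two with the same core have been measured in a functional assay on MRC5 cells (Homo sapiens) for cytotoxicity, read by XTT assay; on this read-out lower numbers stand for higher toxicity in this test and higher numbers for lower toxicity in this test. Compound 1 (`Cc1csc2nc([C@H](C)NC(=O)/C=C/c3ccc(O)cc3Cl)oc(=O)c12`) gives 100 uM. Compound 2 (`Cc1csc2nc([C@H](C)NC(=O)/C=C/c3ccc(Br)s3)oc(=O)c12`) gives 83 uM, which lies within the usual scatter of the value for compound 1. Compound 3 (`Cc1csc2nc([C@H](C)NC(=O)/C=C/c3ccc(Cl)s3)oc(=O)c12`) has chloro in place of bromo on an aromatic carbon, next to the ring sulfur: chloro in place of bromo on an aromatic carbon. Among the compounds with values here, no measured pair shows this exchange itself. Within the data shown here, the only measured step is a 1.2-fold lower number from compound 1 to compound 2 (0.08 log units; within the scatter), and it replaces a whole aromatic group, 2-chloro-4-hydroxyphenyl, with 5-bromothiophen-2-yl. Among the measured compounds shown here, with that step as the only guide, the smaller change here is not expected to move this assay beyond the scatter. The expected step is a 1.0-fold higher number from compound 2 to compound 3 (0.01 log units; within the scatter). For compound 3 the estimated value is 85 uM, with an expected range from 45 uM to 140 uM.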

Compound 3, half-maximal toxic concentration: 130 uM
Beside the measured number, compound 3's estimate is 1.5-fold (0.18 log units) below it, and the stated range covers the measured number.
By their numbers in this assay, from the lowest: compounds 2, 1 and 3 (each within the scatter of the next).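

The exchange of bromo for chloro on this aromatic carbon, next to the ring sulfur, can now be read directly in this assay: it gives a 1.6-fold higher number from compound 2 to compound 3 (0.19 log units; within the scatter), so this test does not separate the two halogens here. Placing 5-chlorothiophen-2-yl in place of 2-chloro-4-hydroxyphenyl gives a 1.3-fold higher number from compound 1 to compound 3 (0.11 log units; within the scatter), which shows that this whole-group exchange also stays within the scatter when the thiophene carries chloro rather than bromo. Nothing available points to a cause for these small differences.

Going by these compounds, whether an amine or a carboxylic acid on this same carbon would give a step beyond the scatter remains open. Also open is how changes to the amide chain or the shared core would read, as every step shown concerns the aromatic group alone.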